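From compound 3 to compound 4: fluoro to hydrogen

This account rests on a few compounds, and the source may have more. Where it says the series, first, only, none or still open, it means among the compounds named here.

Measured compounds:
compound 1 `Cc1cccc(NC(=O)COc2ccc(/C=C3\SC(=O)NC3=O)cc2)n1` gives 58300 nM in a functional assay on PC-3 cells (Homo sapiens) for inhibition; on this read-out lower numbers stand for stronger inhibition of growth and higher numbers for weaker inhibition of growth
compound 2 `O=C(COc1ccc(/C=C2\SC(=O)NC2=O)cc1)Nc1ccc([N+](=O)[O-])cc1` returns only an assay limit, > 100000 nM
compound 3 `O=C(COc1ccc(/C=C2\SC(=O)NC2=O)cc1)Nc1ccc(F)cc1` returns only an assay limit, > 100000 nM

Compound 3 therefore stands at the limit of > 100000 nM in this assay, at which 2 of the 3 values shown sit, with no number of its own; only compound 1 has a readable value. The change to compound 4 `O=C(COc1ccc(/C=C2\SC(=O)NC2=O)cc1)Nc1ccccc1` is hydrogen in place of fluoro on an aromatic carbon. The steps that touch compound 3 are an at least 1.7-fold higher number from compound 1 to compound 3 (0.23 log units; that floor lies within the scatter) and a step that the two limits leave unreadable from compound 2 to compound 3; neither removes a group, and neither has a readable size. Going by the values given here, nothing among the measured steps points to a change beyond the scatter, so compound 4 is expected to show a step of a number no higher from compound 3 to compound 4 (the limit leaves the size open). Compound 4 is estimated at 100000 nM, within a range from 40000 nM to 300000 nM, most likely again reported only as a limit.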

Compound 4, concentration for 50% growth inhibition: > 100000 nM
Compound 4: only a limit was reported (the forecaster's own chance of this, stated with the estimate: 60%); the middle value lies on the limit itself.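

In this assay compound 4, which carries a plain phenyl on the amide nitrogen, gives > 100000 nM, a limit and not a number. With hydrogen at this place, as with fluoro and nitro, no readable value appears, and the steps among these three compounds cannot be read: the limit of > 100000 nM in this assay, at which 3 of the 4 values shown sit. Against the 6-methylpyridin-2-yl amide, the change reads as an at least 1.7-fold higher number from compound 1 to compound 4 (0.23 log units; that floor lies within the scatter). On these data alone, whether an amine or a carboxylic acid at this place would give a readable number stays open. Also open, as far as these compounds go, is what the methyl group contributes to compound 1, at 58300 nM.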